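Aryl hydrazone exchange on the shared core, compound 3 to 4

The compounds below may be only part of what the source reports. "The series", "measured", "known", "first", "only" and "open" are said of these compounds alone.

Compound 3 `CCCSc1nc(N/N=C/c2cccs2)c2nnn(Cc3ccccc3)c2n1` is measured in a functional assay on ECa-109 cells (Homo sapiens) for antiproliferative activity, read by MTT assay, with a stated time of 72 h (on this read-out higher numbers stand for weaker inhibition and lower numbers for stronger inhibition), and returns only a limit, > 64000 nM, so its standing is known as a limit and not as a number. Compound 1 `CCCSc1nc(N/N=C(\C)c2ccc(OC)cc2)c2nnn(Cc3ccccc3)c2n1` also returns a limit in this assay, > 64000 nM. Compound 2 `CCCSc1nc(N/N=C(\C)c2ccccc2O)c2nnn(Cc3ccco3)c2n1` gives a measured value in this assay of 5760 nM. Within the data shown here, compound 3 therefore sits at the limit of > 64000 nM in this assay, at which 2 of the 3 values shown sit, and compound 2 is the one compound with a number.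

Compound 4 `CCCSc1nc(N/N=C(\C)c2ccccc2O)c2nnn(Cc3ccccc3)c2n1` is not yet measured. It differs from compound 3 by a group of 10 heavy atoms (8 carbon, 1 nitrogen, 1 oxygen; one six-membered aromatic ring of carbon only) in place of a group of 7 heavy atoms (5 carbon, 1 nitrogen, 1 sulfur; one five-membered aromatic ring with 1 hetero atom), on a nitrogen on an aromatic ring. Among the measured compounds shown here, no step between measured compounds is available, so the size of the step is inferred only from what the values show. Compound 4 carries the same group on that nitrogen as compound 2, while the rest of its structure matches compound 3. Compound 2 shows this group going with a measurable value, whereas compound 3 sits at a limit. A gain beyond the scatter is expected, from the limit into the measured range, though the limit leaves the true size open. The estimate for compound 4 is 10000 nM, with a range from 3000 nM to 40000 nM. The expected step is an at least 6.4-fold lower number from compound 3 to compound 4 (0.80 log units; beyond the scatter).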

Compound 4, half-maximal inhibitory concentration: 11100 nM
Compound 4: the middle estimate sits 1.1-fold (0.05 log units) below what was measured; the measured number falls inside the stated range.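

With phenyl held on the saturated chain carbon, 2-hydroxyphenyl in place of 4-methoxyphenyl on a carbon with a double bond to nitrogen gives an at least 5.7-fold lower number from compound 1 to compound 4 (0.76 log units; beyond the scatter) in this assay, and the larger exchange on a nitrogen on an aromatic ring gives an at least 5.7-fold lower number from compound 3 to compound 4 (0.76 log units; beyond the scatter). Phenyl in place of furan-2-yl on a saturated chain carbon bound to an aromatic nitrogen gives a 1.9-fold higher number from compound 2 to compound 4 (0.28 log units; within the scatter), so among these compounds the measurable value does not rest on furan-2-yl. Both gains start from a limit, so their true size stays open: the limit of > 64000 nM in this assay, at which 2 of the 4 values shown sit.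

Going by these compounds, whether the gain belongs to the hydroxy group itself or to its place on the ring remains open, and 2-methoxyphenyl or 2-aminophenyl on that carbon would bear on this. On these data alone, how an amine or a carboxylic acid on the phenyl of the saturated chain carbon would read also remains open.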